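Working notes: cytotoxicity across the aminopyrimidine series, compound 3

The source may report more compounds than this note shows. Statements on the series, on what has been measured and on what is new or still open speak of the compounds shown alone.

In an ADME assay on cells (Homo sapiens) for cytotoxicity, read by polymerase chain reaction, with a stated time of 3 days (a higher number here means that more compound is tolerated, a lower number that less compound is tolerated), compound 1, `Cc1nc(N(C)C)nc(N[C@@H]2C[C@H](CO)[C@@H](O)[C@H]2O)c1-c1nc2ccccc2s1`, gives 18000 nM. For compound 2, `Cc1nc(NCCNS(C)(=O)=O)nc(N[C@@H]2C[C@H](CO)[C@@H](O)[C@H]2O)c1-c1nc2ccccc2s1`, this assay returns only a limit, > 25000 nM, so its standing on the numbers is open-ended: the measured step of an at least 1.3-fold higher number from compound 1 to compound 2 (0.14 log units; that floor lies within the scatter) is a floor rather than a fixed size, and it rests on (the limit of > 25000 nM in this assay, at which 1 of the 2 values shown sits). Compound 3, `Cc1nc(NCc2ccccc2)nc(N[C@@H]2C[C@H](CO)[C@@H](O)[C@H]2O)c1-c1nc2ccccc2s1`, has not yet been measured in this assay. It differs from compound 2 by phenyl in place of (methanesulfonamido)methyl on a saturated chain carbon bound to a nitrogen on an aromatic ring; seen one bond further out, this is benzylamino in place of (2-(methanesulfonamido)ethyl)amino. Within the data shown here, only the single step from compound 1 to compound 2 bears on the question, and it sits within the scatter, so nothing here points to a change in tolerated concentration beyond the scatter for compound 3. The two measured values give a working band for this scaffold, and compound 3 is expected to fall inside it. For compound 3 the expected step is an at least 1.5-fold lower number from compound 2 to compound 3 (0.19 log units; that floor lies within the scatter). The estimate for compound 3 is 16000 nM, spanning from 5000 nM to 25000 nM.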

Compound 3, half-maximal cytotoxic concentration: 9000 nM
For compound 3 the middle estimate is 1.8-fold (0.25 log units) above the measured one, within the range that was stated.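

In this assay, phenyl in place of (methanesulfonamido)methyl on a saturated chain carbon bound to a nitrogen on an aromatic ring gives an at least 2.7-fold lower number from compound 2 to compound 3 (0.44 log units; beyond the scatter), the first step among these compounds that clears the scatter. Among these compounds, that size is a floor and not a fixed value, and the true gap stays unknown: the limit of > 25000 nM in this assay, at which 1 of the 3 values shown sits. Benzylamino in place of dimethylamino on an aromatic carbon gives a 2.0-fold lower number from compound 1 to compound 3 (0.30 log units; within the scatter), so this change does not separate the two groups, and only the pair carrying benzylamino and (2-(methanesulfonamido)ethyl)amino stands apart.

The compounds shown do not tell whether the step follows the arrival of phenyl or the departure of the methanesulfonamido group, as both change in the same swap. From the compounds shown here alone, a plain (2-hydroxyethyl)amino group, a longer chain such as 3-phenylpropylamino, or a benzylamino group with a chlorine on its ring remains open at this place, as does any reading of whether the trend holds beyond these three compounds.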